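A few compounds are considered here, and "the series" means these few. Any claim that something is new, unique, unknown or untested is made for them only; others in the source may bear on it.

Compound 2 `COc1ccc(/C=N/Nc2nc(C)cs2)cc1` gives 19.1 nM in an assay on mitochondria for inhibition of Amine oxidase [flavin-containing] A (Bos taurus); on this read-out higher numbers stand for weaker inhibition and lower numbers for stronger inhibition. Among the three measured compounds it sits at the low end of the numbers: compound 1 `Cc1csc(N/N=C/c2ccc(Cl)cc2)n1` gives 38 nM, with a 2.0-fold lower number from compound 1 to compound 2 (0.30 log units; within the scatter), and compound 3 `COc1ccc(/C=N/Nc2nc(-c3ccccc3)cs2)cc1` gives 50.1 nM, with a 2.6-fold higher number from compound 2 to compound 3 (0.42 log units; beyond the scatter). Compound 4 `COc1ccc(/C=N/Nc2nc(C)cs2)cc1OC` differs from compound 2 by methoxy in place of hydrogen on an aromatic carbon. Going by the values given here, only one measured step touches the same six-membered aromatic ring of carbon only, the exchange of substituent seen in a 2.0-fold lower number from compound 1 to compound 2 (0.30 log units; within the scatter), and that step stayed within the scatter; the step of a 2.6-fold higher number from compound 2 to compound 3 (0.42 log units; beyond the scatter) concerns the other end of the molecule and says nothing about an added methoxy. Among the compounds with values here, no measured pair adds a second group to that ring, so the data give no pointer to a shift in either direction beyond the scatter. The expected step is therefore a 1.3-fold higher number from compound 2 to compound 4 (0.12 log units; within the scatter), a movement kept inside the usual scatter. Compound 4 is expected to give 25 nM in this assay, with a range from 10 nM to 65 nM.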

Compound 4, inhibition constant: 13.2 nM
Beside the measured number, compound 4's estimate is 1.9-fold (0.28 log units) above it; the range from low to high includes it.
By their numbers in this assay, from the lowest: compounds 4, 2, 1 and 3 (each within the scatter of the next, the first and the last beyond it).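

In this assay, the methoxy added on the six-membered aromatic ring of carbon only, ortho to a methoxy group and meta to a group of 9 heavy atoms, gives a step within the scatter (a 1.4-fold lower number from compound 2 to compound 4 (0.16 log units; within the scatter)). Earlier compounds only showed one group exchanged for another on this ring, whereas this pair shows that a ring position carrying hydrogen in compound 2 also accepts methoxy without a step beyond the scatter. No supporting measurement is available to explain this outcome.

As far as these compounds go, whether an amine, a carboxylic acid or a longer chain such as ethoxy at this position would give a step beyond the scatter remains open. From the compounds shown here alone, it is also open whether the added methoxy would give a similar step with phenyl in place of methyl, as in compound 3.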